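This account rests on a few compounds, and the source may have more. Where it says the series, first, only, none or still open, it means among the compounds named here.

Of the compounds shown here, three have been measured in a functional assay on LNCaP cells (Homo sapiens) for cytotoxicity, read by MTT assay, with a stated time of 72 h; on this read-out lower numbers stand for stronger inhibition and higher numbers for weaker inhibition. Compound 1 `CC1=C(/C=C/C(=O)/C=C/c2ccc(C(F)(F)F)cc2)C(C)(C)CCC1` gives 9100 nM, and compound 2 `CC1=C(/C=C/C(=O)/C=C/c2ccc(F)cc2)C(C)(C)CCC1` gives 7300 nM. Compound 2 differs from compound 1 in one place, (fluoro in place of trifluoromethyl on an aromatic carbon), and the step measured between them is a 1.2-fold lower number from compound 1 to compound 2 (0.10 log units; within the scatter). Compound 3 `CC1=C(/C=C/C(=O)/C=C/c2ccccc2C(F)(F)F)C(C)(C)CCC1O` gives 2900 nM, the lowest of the three numbers; the difference between its core and the core of compound 1 is not broken down here. Compound 4 `CC1=C(/C=C/C(=O)/C=C/c2ccccc2F)C(C)(C)CCC1O` has not yet been measured. It differs from compound 3 by fluoro in place of trifluoromethyl on an aromatic carbon. Among the compounds with values here, this is the same kind of change as the one from compound 1 to compound 2, though the earlier one sits para to a large group and this one ortho to a large group. Beside the earlier step, a 1.1-fold lower number from compound 3 to compound 4 (0.05 log units; within the scatter) is expected, because a 1.2-fold lower number from compound 1 to compound 2 (0.10 log units; within the scatter) lay within the scatter. Compound 4 is therefore estimated at 2600 nM, between 1200 nM and 5800 nM.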

Compound 4, half-maximal inhibitory concentration: 2900 nM
Estimate against measurement, compound 4: 1.1-fold (0.05 log units) below; the measured number falls inside the stated range.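

In this assay, putting fluoro in place of trifluoromethyl gives no change at the digits printed from compound 3 to compound 4 (within the scatter), and this matches the same change on the other core: the same change on two cores in this assay, a 1.2-fold lower number (0.10 log units; within the scatter) from compound 1 to compound 2 and no change at the digits printed (within the scatter) from compound 3 to compound 4, 1.2-fold (0.10 log units) apart, within the scatter of two such steps So in these two pairs the change carried from one core to the other without a step beyond the scatter, and the swap left the number effectively unchanged each time. This does not show that it would behave the same way on every core in the series, and the two pairs cannot separate the effect of the core from that of where the group sits on the ring, since both differ.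

The compounds shown leave open whether an amine, a nitrile or a carboxylic acid on that aromatic carbon would move the number.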